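Trading the acid-bearing ring for a methoxyphenyl

The source may hold more compounds than are shown below. What is called first, only, known or untested is meant among the compounds shown, and "the series" means these compounds.

Of the compounds shown here, three have been measured in an assay for positive allosteric modulation of metabotropic glutamate receptor 3 (Rattus norvegicus); on this read-out higher numbers stand for an effect only at larger amounts of compound and lower numbers for an effect already at smaller amounts. Compound 1 `COc1cc(OCCCCOc2ccc(C(=O)CC(C)(C)C)c(O)c2C)cc(C(=O)O)c1` gives 703 nM. Compound 2 `Cc1c(O[C@@H](C)COc2ccc(F)c(C(=O)O)c2)ccc(C(=O)CC(C)(C)C)c1O` gives 1120 nM. Compound 3 `Cc1cc(C(=O)O)ccc1OC[C@H](C)COc1ccc(C(=O)CC(C)(C)C)c(O)c1C` gives 1520 nM, the highest of the three numbers; its gap to compound 2 lies within the scatter, while its gap to compound 1 lies beyond it. No pair among these three differs in a single place, so the numbers stand side by side without a step between them.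

Compound 4 `COc1cccc(OC[C@H](C)COc2ccc(C(=O)CC(C)(C)C)c(O)c2C)c1` has not yet been measured. It differs from compound 3 in one place: 3-methoxyphenyl in place of 4-carboxy-2-methylphenyl on an oxygen on a saturated carbon. Among the compounds with values here, each of the three measured compounds carries a carboxylic acid on one of its aromatic rings, and none of them shows what happens when that group is absent; the data therefore give no step on which to rest this change. In this assay the step from compound 3 to compound 4 is expected to run toward higher numbers, estimated as a 1.6-fold higher number from compound 3 to compound 4 (0.22 log units; within the scatter), a step that may reach beyond the scatter but is uncertain. Compound 4 is expected to come in at about 2500 nM, with a range from 800 nM to 8000 nM.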

Compound 4, half-maximal effective concentration: "not active" (no number reported)
No number was reported for compound 4, so the estimate cannot be set against anything.
By their numbers in this assay, from the lowest: compounds 1, 2 and 3 (each within the scatter of the next, the first and the last beyond it).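

In this assay, within the data shown here, compound 4 is reported as not active, without a number, so no step from compound 3 to compound 4 can be read. Nothing shown here explains this result. The compounds shown leave open whether the carboxy group alone or the whole 4-carboxy-2-methylphenyl group separates compound 3 from compound 4.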